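Removing the Last Halogen From the Indazole Ring

The source may report more compounds than this note shows. Statements on the series, on what has been measured and on what is new or still open speak of the compounds shown alone.

Three ureas share one core and differ only in the group on the fused ring. Compound 1 `O=C(Nc1ccc(-n2ncc3c(C(F)(F)F)cccc32)cc1)Nc1ccc(Cl)c(C(F)(F)F)c1` gives 2000 nM in a functional assay on MDA-MB-231 cells (Homo sapiens) for cytotoxicity, read by MTT assay, with a stated time of 72 h; on this read-out higher numbers stand for weaker inhibition and lower numbers for stronger inhibition. Compound 2 `O=C(Nc1ccc(-n2ncc3c(Cl)cccc32)cc1)Nc1ccc(Cl)c(C(F)(F)F)c1` gives 1600 nM, and compound 3 `O=C(Nc1ccc(-n2ncc3c(F)cccc32)cc1)Nc1ccc(Cl)c(C(F)(F)F)c1` gives 3100 nM. Compound 3 is not set apart from the others: a 1.6-fold higher number from compound 1 to compound 3 (0.19 log units; within the scatter) and a 1.9-fold higher number from compound 2 to compound 3 (0.29 log units; within the scatter), just as a 1.3-fold lower number from compound 1 to compound 2 (0.10 log units; within the scatter). Compound 4 `O=C(Nc1ccc(-n2ncc3ccccc32)cc1)Nc1ccc(Cl)c(C(F)(F)F)c1` carries hydrogen in place of fluoro on an aromatic carbon. For the measured compounds named here, no measured step removes a group outright, but every swap among trifluoromethyl, chloro and fluoro stayed within the scatter, so the number for compound 4 is expected to sit close to that of compound 3, with a 1.1-fold higher number from compound 3 to compound 4 (0.05 log units; within the scatter). Compound 4 is estimated at 3500 nM, between 1500 nM and 8000 nM.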

Compound 4, half-maximal inhibitory concentration: 5000 nM
Estimate against measurement, compound 4: 1.4-fold (0.15 log units) below; the measured number falls inside the stated range.
By their numbers in this assay, from the lowest: compounds 2, 1, 3 and 4 (each within the scatter of the next, the first and the last beyond it).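

For the compounds shown here, with hydrogen on this aromatic carbon, this assay shows the first steps beyond the scatter at this position: a 3.1-fold higher number from compound 2 to compound 4 (0.49 log units; beyond the scatter) and a 2.5-fold higher number from compound 1 to compound 4 (0.40 log units; beyond the scatter) are both modest, while swaps among the three halogen-bearing groups stayed within it. Compound 3 goes against any simple gain from a group here, as a 1.6-fold higher number from compound 3 to compound 4 (0.21 log units; within the scatter) leaves fluoro and hydrogen not told apart. No measurement shown accounts for these steps.

From the compounds shown here alone, whether an amine, a methoxy group or a carboxylic acid on this carbon would give a lower or higher number remains open. So does whether these steps would hold with other groups on the rest of the shared core.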